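The source may report more compounds than this note shows. Statements on the series, on what has been measured and on what is new or still open speak of the compounds shown alone.

Working notes on the series. In a physicochemical assay for solubility, with a stated time of 24 h, at pH 2.2 (on this read-out lower numbers stand for lower solubility and higher numbers for higher solubility), compound 1 `O=C(Nc1cc2cccccc-2c1)c1cccnc1` gives 43 ug/mL. Compound 2 `COC(=O)c1ccc2ccc(C(=O)N(C)C)c-2cc1` gives > 64 ug/mL in this assay, which is a limit of the assay and not a number. From the compounds shown here alone, compound 2 thus sits at the limit of > 64 ug/mL in this assay, at which 1 of the 2 values shown sits, and its true value remains open. Compound 3 `COC(=O)c1ccc2ccc(C(=O)c3ccccc3)c-2cc1` follows from compound 2 by one change, phenyl in place of dimethylamino on a carbonyl carbon. For the measured compounds named here, no measured step covers this exchange. A fall beyond the usual scatter is expected, with an estimated at least 6.4-fold lower number from compound 2 to compound 3 (0.80 log units; beyond the scatter). For compound 3 the estimated value is 10 ug/mL, with an expected range of 2 ug/mL to 40 ug/mL.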

Compound 3, solubility: < 1 ug/mL
Compound 3 was reported as a limit; the forecaster's own chance of this, stated with the estimate: 15%; middle value at least 10-fold (1.00 log units) from the limit.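

Phenyl in place of dimethylamino on a carbonyl carbon is the first exchange that can be read in this assay, and it gives an at least 64-fold lower number from compound 2 to compound 3 (1.80 log units; beyond the scatter). Compound 3 stands at a limit of the assay and not at a number: the limit of < 1 ug/mL in this assay, at which 1 of the 3 values shown sits. Compound 2 also stands at a limit of the assay and not at a number: the limit of > 64 ug/mL in this assay, at which 1 of the 3 values shown sits.

From the compounds shown here alone, the full size of the step remains open. Also open, going by these compounds, is whether the aromatic ring or the loss of the nitrogen goes with the fall, which a cyclohexyl or a piperidine on the same carbonyl carbon could separate.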